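Moving the double bond of compound 2 from E to Z

This account rests on a few compounds, and the source may have more. Where it says the series, first, only, none or still open, it means among the compounds named here.

Measured in a functional assay on cells (Endothelial cell, Bos taurus) for antiproliferative activity; a higher number here means a weaker inhibitor, a lower number a stronger inhibitor:
compound 1 `COc1ccc(/C(F)=C/c2cc(OC)c(OC)c(OC)c2)cc1[N+](=O)[O-]` gives > 3000000 nM
compound 2 `COc1cc(/C(F)=C\c2cc(O)c3ccoc3c2)cc(OC)c1OC` gives 170 nM

Within the data shown here, only two compounds have been measured in this assay so far, and just one of them has yielded a number. Compound 1 reached the limit of the assay at > 3000000 nM, which is a limit and not a number. Among the measured compounds shown here, compound 2 gives 170 nM, the only true number in hand, and so it is the sole reference point.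

The next compound is compound 3 `COc1cc(/C(F)=C/c2cc(O)c3ccoc3c2)cc(OC)c1OC`, and the change is a small one: the two compounds have the same atoms and bonds and differ only in configuration as drawn: 1 of 1 stereo elements differ; a double bond is drawn E in compound 2 and Z in compound 3. The two compounds have the same atoms and bonds, and a double bond is drawn E in compound 2 and Z in compound 3. For the measured compounds named here, no measured step shows what such a change does, so the size of the shift is a judgement. A clear loss of potency, well beyond the scatter, is expected, starting from the 170 nM of compound 2. The expected change is a 59-fold higher number from compound 2 to compound 3 (1.77 log units; beyond the scatter). For compound 3 the estimated value is 10000 nM, within an expected range of 1000 nM to 100000 nM.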

Compound 3, half-maximal inhibitory concentration: > 1000 nM
Compound 3: only a limit was reported (the forecaster's own chance of this, stated with the estimate: 30%); the middle value is on the limit's open side.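

In this assay, compound 1 differs from compound 2 in more than one place and could say nothing about the double bond, whereas this pair isolates it, with the step being an at least 5.8-fold higher number from compound 2 to compound 3 (0.76 log units; beyond the scatter). Compound 3 gives > 1000 nM, which is a limit and not a number. With nothing entering or leaving, the loss of potency at this double bond can be tied to its configuration alone, and the 170-level activity of the earlier reference is therefore not kept once the configuration changes: the fact that compounds 2 and 3 differ only in the configuration as drawn

The compounds shown leave open whether compound 2, with its 170 nM, would hold its potency with an amine or a carboxylic acid added to the shared core. They also leave open whether the configuration of the double bond would matter to the same degree if a nitrile took the place of the fluorine, and how far the potency of compound 3 really lies from that of compound 2.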